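Swapping one halogenated phenyl for another on a shared core

The source may report more compounds than this note shows. Statements on the series, on what has been measured and on what is new or still open speak of the compounds shown alone.

Compound 1 `O=C1/C(=C\c2cccc(Oc3ccccc3)c2)c2ccccc2N1c1c(Cl)cccc1Cl` gives 100 ug/mL in a functional assay on MCF7 cells (Homo sapiens) for cytotoxicity, read by MTT assay, with a stated time of 72 h; on this read-out lower numbers stand for an effect already at smaller amounts and higher numbers for an effect only at larger amounts of compound. Compound 2 `O=C1/C(=C\c2cccc(Br)c2)c2ccccc2N1c1c(Cl)cccc1Cl` gives 5 ug/mL in this assay. Within the data shown here, the step of a 20-fold lower number from compound 1 to compound 2 (1.30 log units; beyond the scatter) is the only change measured so far. Among the measured compounds shown here, compound 2 therefore stands with the lowest number of the two, with compound 1 its only neighbour, a clearly higher one.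

Compound 3 `O=C1/C(=C\c2ccc(Cl)cc2)c2ccccc2N1c1c(Cl)cccc1Cl` is not yet measured. It differs from compound 2 by 4-chlorophenyl in place of 3-bromophenyl on a double-bonded chain carbon bound to a double-bonded ring carbon. For the measured compounds named here, the one measured step, from a phenoxy to a bromo group, does not match this change, so no direct guide exists. Both compound 2 and compound 3 carry a single halogen on that phenyl, and for that reason a step within the scatter is expected, a 1.6-fold higher number from compound 2 to compound 3 (0.20 log units; within the scatter). Compound 3 is estimated at 8 ug/mL in this assay, within a range from 2 ug/mL to 30 ug/mL.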

Compound 3, concentration for half-maximal effect: 5 ug/mL
Compound 3: the middle estimate sits 1.6-fold (0.20 log units) above what was measured; the range from low to high includes it.
By their numbers in this assay, from the lowest: compounds 2 and 3 (each within the scatter of the next); then compound 1.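

Replacing 3-bromophenyl with 4-chlorophenyl on the double-bonded chain carbon gives no change at the digits printed from compound 2 to compound 3 (within the scatter) in this assay, so this exchange leaves the read-out unchanged, unlike the large step from phenoxy to bromo seen earlier, a 20-fold lower number from compound 1 to compound 2 (1.30 log units; beyond the scatter). The new result shows that this position does not respond to every change of its aromatic group: the halogen and its location on the phenyl differ together here without a visible effect, although the two changes cannot be separated. Nothing available explains why this exchange makes no difference.

The compounds shown leave open whether either change alone would also leave the number in place. They also leave open how a phenyl carrying an amine or a carboxylic acid would compare with these halogenated phenyl groups.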